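The source may report more compounds than this note shows. Statements on the series, on what has been measured and on what is new or still open speak of the compounds shown alone.

Measured so far in a functional assay on SH-SY5Y cells (Homo sapiens) for cytotoxicity, read by MTT assay, with stated times of 24 h and 4 h; on this read-out higher numbers stand for an effect only at larger amounts of compound and lower numbers for an effect already at smaller amounts:
compound 1 `COc1cc(CNC(=O)/C=C/c2cccc(OCc3nc(C)c(C)nc3C)c2)ccc1O` gives 8090 nM;
compound 2 `COc1cc(CNC(=O)/C=C/c2cccc(OCc3nc(C)c(C)nc3C)c2)ccc1OCc1nc(C)c(C)nc1C` gives 8700 nM;
compound 3 `COc1cc(/C=C/C(=O)NCc2ccc(OCc3nc(C)c(C)nc3C)c(OC)c2)ccc1O` gives 13400 nM.

Compound 1 and compound 2 differ in one place only, ((3,5,6-trimethylpyrazin-2-yl)methyl in place of hydrogen on an oxygen on an aromatic ring). In this assay this change produced a 1.1-fold higher number from compound 1 to compound 2 (0.03 log units; within the scatter), so the two values are effectively indistinguishable. Compound 3 is built on a different core; the difference between the two cores is not broken down here, and its value sits within the scatter of both compound 1 and compound 2.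

Compound 4 `COc1cc(/C=C/C(=O)NCc2ccc(OCc3nc(C)c(C)nc3C)c(OC)c2)ccc1OCc1nc(C)c(C)nc1C` has not yet been measured in this assay. It differs from compound 3 by (3,5,6-trimethylpyrazin-2-yl)methyl in place of hydrogen on an oxygen on an aromatic ring, the same change that separates compound 1 from compound 2. Because that earlier change gave a 1.1-fold higher number from compound 1 to compound 2 (0.03 log units; within the scatter), the corresponding step is expected to be small as well. The step from compound 3 to compound 4 is therefore expected to be about a 1.1-fold higher number from compound 3 to compound 4 (0.05 log units; within the scatter). Compound 4 is estimated at 15000 nM, most likely between 7500 nM and 30000 nM.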

Compound 4, half-maximal effective concentration: 11100 nM
The estimate for compound 4 lay 1.4-fold (0.13 log units) above the measured number, and the stated range covers the measured number.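

In this assay, putting (3,5,6-trimethylpyrazin-2-yl)methyl in place of hydrogen on an oxygen on an aromatic ring gives a 1.2-fold lower number from compound 3 to compound 4 (0.08 log units; within the scatter), so the number does not measurably move. The earlier case on the other core agrees with this, and the two steps cannot be told apart: the same change on two cores in this assay, a 1.1-fold higher number (0.03 log units; within the scatter) from compound 1 to compound 2 and a 1.2-fold lower number (0.08 log units; within the scatter) from compound 3 to compound 4, 1.3-fold (0.11 log units) apart, within the scatter of two such steps. This shows that the change carries over between these two cores with no measurable effect on either, but two cores cannot show that it would do the same on a third. The compounds shown leave open whether a different group on that oxygen, such as a longer chain ending in an amine or a carboxylic acid, would move the number beyond the scatter.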